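Extending a Weak Carbamate Series with a Dimethoxyphenyl Group

A few compounds are considered here, and "the series" means these few. Any claim that something is new, unique, unknown or untested is made for them only; others in the source may bear on it.

Three carbamates sharing the core of compound 1 `CC(C)c1cccc(C(C)C)c1OC(=O)NS(=O)(=O)N1CCCC1` were examined in an assay on liver for inhibition of sterol O-acyltransferase 1 (Rattus norvegicus), using microsomes; on this read-out higher numbers stand for weaker inhibition and lower numbers for stronger inhibition. Compound 1 gives 53000 nM. Compound 2 `CC(C)c1cccc(C(C)C)c1OC(=O)NS(=O)(=O)N1CCOCC1` reaches only the limit of > 100000 nM in this assay. Compound 3 `CC(C)c1cccc(C(C)C)c1OC(=O)NS(=O)(=O)Oc1ccccc1` likewise stands at a limit, > 50000 nM, in this assay. Within the series, an at least 1.8-fold higher number from compound 1 to compound 2 (0.27 log units; that floor lies within the scatter) was observed. The remaining two steps, a step that the limit leaves unreadable from compound 1 to compound 3 and a step that the two limits leave unreadable from compound 2 to compound 3, cannot be sized. Compound 4 `COc1cccc(OC)c1OS(=O)(=O)NC(=O)Oc1c(C(C)C)cccc1C(C)C` differs from compound 3 by 2,6-dimethoxyphenyl in place of phenyl on an oxygen. Among the compounds with values here, no measured step bears directly on this change, and compound 3 is itself only a limit. A small step is expected, a step that the limit leaves unreadable from compound 3 to compound 4. Compound 4 is therefore estimated at 60000 nM, with a range from 10000 nM to 300000 nM.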

Compound 4, half-maximal inhibitory concentration: > 50000 nM
Compound 4: no number, only a limit; the forecaster's own chance of this, stated with the estimate: 60%; the middle value is on the limit's open side.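

In this assay compound 4 gives only a limit, > 50000 nM. Within the data shown here, compound 3 also stands at a limit, so no step from compound 3 to compound 4 can be read. The compounds shown leave open whether 2,6-dimethoxyphenyl in place of phenyl on an oxygen changes inhibition at all.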